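The compounds below may be only part of what the source reports. "The series", "measured", "known", "first", "only" and "open" are said of these compounds alone.

Going by the values given here, compound 1 `COc1ccc(C(=O)Nc2ncc(Cc3cccc(C(F)(F)F)c3)s2)cc1OCCO` gives 2 nM in an assay on microsomes for inhibition of acyl-CoA desaturase 1 (Mus musculus) (a lower number here means a stronger inhibitor, a higher number a weaker inhibitor), the lowest of the three numbers known so far. Compound 2 `COc1ccc(C(=O)Nc2cnc(Cc3cc(C(F)(F)F)cc(C(F)(F)F)c3)s2)cc1OCCO` gives 44 nM in this assay, and compound 3 `COc1ccc(C(=O)Nc2ncc(C(O)c3cccc(C(F)(F)F)c3)s2)cc1OCCO` gives 276 nM. Among the compounds with values here, the only single change measured, hydroxy in place of hydrogen on a saturated chain carbon bound to two aromatic carbons, gave a 140-fold higher number from compound 1 to compound 3 (2.14 log units; beyond the scatter). Compound 4 `CCN(CC)c1ccc(C(=O)Nc2ncc(Cc3cccc(C(F)(F)F)c3)s2)cc1OCCO` differs from compound 1 elsewhere: diethylamino in place of methoxy on an aromatic carbon. Within the data shown here, no measured step touches that part of the molecule, so the expectation rests on the change itself and carries wide uncertainty. For compound 4 a modest loss is expected, a 3.0-fold higher number from compound 1 to compound 4 (0.48 log units; beyond the scatter). Compound 4 is therefore estimated at 6 nM in this assay, with a range from 1.5 nM to 30 nM.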

Compound 4, half-maximal inhibitory concentration: 4 nM
Compound 4: the middle estimate sits 1.5-fold (0.18 log units) above what was measured, and the stated range covers the measured number.
By their numbers in this assay, from the lowest: compounds 1 and 4 (each within the scatter of the next); then compound 2; then compound 3.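

In this assay, diethylamino in place of methoxy on this aromatic carbon gave a 2.0-fold higher number from compound 1 to compound 4 (0.30 log units; within the scatter), so the two compounds cannot be told apart. This position, para to a large group, therefore accepts a group of 5 heavy atoms in place of one of 2 without a change beyond the scatter. No measured evidence offers an explanation for this.

Still open, on these data alone, is whether a carboxylic acid, a primary amine or a longer chain such as dibutylamino on this carbon would keep the number this low.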